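Thiazole acid series: benzyl substituent, fluorination step

A few compounds are considered here, and "the series" means these few. Any claim that something is new, unique, unknown or untested is made for them only; others in the source may bear on it.

Of the compounds shown here, two carry numbers so far. Compound 1 `Cc1nc(-c2ccc3c(c2)c(C#N)cn3C(C)C)sc1C(=O)O` gives 60% in a functional assay on the whole organism (strain Sprague-Dawley) for inhibition, with Rattus norvegicus as the target, with a stated time of 1 h, at a dose of 10 mg/kg by the oral route; on this read-out higher numbers stand for more inhibition at the one dose given (going by the name of the read-out) and lower numbers for less inhibition. Going by the values given here, compound 2 `Cc1nc(-c2ccc3c(c2)c(C#N)cn3Cc2ccccc2)sc1C(=O)O` gives 10% in this assay, the lowest of the two numbers; the only step measured, a number 50 percentage points lower from compound 1 to compound 2 (beyond the scatter), comes from benzyl in place of isopropyl on an aromatic nitrogen.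

Compound 3 `Cc1nc(-c2ccc3c(c2)c(C#N)cn3Cc2ccc(F)cc2F)sc1C(=O)O` differs from compound 2 by 2,4-difluorophenyl in place of phenyl on a saturated chain carbon bound to an aromatic nitrogen. Among the compounds with values here, no measured step touches a change of this kind: the one step in hand alters the group on the aromatic nitrogen as a whole, not a substituent on the phenyl of the benzyl, so it gives no direction for this change. With the benzyl kept and only fluorines added, the expectation for compound 3 rests on compound 2 alone, and the expected step is a number 5 percentage points higher from compound 2 to compound 3 (within the scatter), that is, nothing expected beyond the scatter. Compound 3 is therefore estimated at 15% in this assay, with a range from 0% to 40%.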

Compound 3, a percentage reported as inhibition, in the whole organism at one dose (the size of the read-out at that dose, not a potency): 16%
The estimate for compound 3 lay 1 percentage points below the measured number, and the stated range covers the measured number.
By their numbers in this assay, from the lowest: compounds 2 and 3 (each within the scatter of the next); then compound 1.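

In this assay, the change on the saturated chain carbon bound to the aromatic nitrogen gives a number 6 percentage points higher from compound 2 to compound 3 (within the scatter) and so does not separate 2,4-difluorophenyl from phenyl at this position. Replacing isopropyl on the aromatic nitrogen with 2,4-difluorobenzyl gives a number 44 percentage points lower from compound 1 to compound 3 (beyond the scatter) and so leaves a gap beyond the scatter, as with benzyl in a number 50 percentage points lower from compound 1 to compound 2 (beyond the scatter), which shows that these two fluorines do not restore the level of compound 1 at the one dose given. No supporting data bear on why the fluorines make no clear difference here.

Open questions are whether a cyclopentyl or tert-butyl group on the aromatic nitrogen would match or exceed compound 1, and whether a methoxy group or an amine on the phenyl of the benzyl would shift the read-out beyond the scatter. Also open, on these data alone, is how a longer chain, such as n-butyl, would compare with isopropyl.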